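The compounds below may be only part of what the source reports. "The series", "measured", "known", "first", "only" and "open" are said of these compounds alone.

Measured so far: compound 1 `CC(=O)N[C@@H](C)C(=O)N(C)/N=N/c1ccc(Br)cc1` with 2.8 in a physicochemical assay for lipophilicity, read by HPLC, in phosphate buffer, measured as octanol-water partition, at pH 7.4 (a lower number here means a more polar compound, a higher number a more lipophilic compound), and compound 2 `CCCC(=O)N[C@@H](C)C(=O)N(C)/N=N/c1ccc(C#N)cc1` with 2.28 in this assay.

Within the data shown here, of these two numbers, compound 2 has the lower one; its only neighbour, compound 1, gives a higher reading in this assay, and the gap between them is beyond the scatter.

Compound 3 `C[C@H](NC(=O)c1ccccc1)C(=O)N(C)/N=N/c1ccc(C#N)cc1` is not yet measured. It differs from compound 2 by phenyl in place of propyl on a carbonyl carbon. Among the measured compounds shown here, no comparable step between measured compounds is known. For this change compound 3 is expected to read somewhat higher than compound 2 in this assay, a step of a number 0.42 log units higher from compound 2 to compound 3 (beyond the scatter). The estimate for compound 3 is 2.7, with a range from 2.3 to 3.2.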

Compound 3, partition coefficient: 3.04
Beside the measured number, compound 3's estimate is 0.34 log units below it; low and high end bracket the measured number.
By their numbers in this assay, from the lowest: compound 2; then compounds 1 and 3 (each within the scatter of the next).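

In this assay, among these compounds, phenyl in place of propyl on a carbonyl carbon gives a number 0.76 log units higher from compound 2 to compound 3 (beyond the scatter) as the only step here that changes one place. It shows that the reading responds to the group at this position while the rest of compound 2 stays the same. Because the step adds a six-membered aromatic ring and also changes the carbon count, it does not separate these two differences, and no measurement at hand accounts for its size.

On these data alone, it remains open whether a longer chain on this carbonyl carbon would read closer to compound 2 or to compound 3. As far as these compounds go, the reading with an amine at this position also remains open.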